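Fluoro to Iodo at the Limit of Detection

The source may report more compounds than this note shows. Statements on the series, on what has been measured and on what is new or still open speak of the compounds shown alone.

Measured so far in a functional assay on cells (Splenocyte, Mus musculus, strain BALB/c) for inhibition, read by scintillation counting and thymidine incorporation, with a stated time of 72 h; on this read-out lower numbers stand for stronger inhibition and higher numbers for weaker inhibition:
Compound 1, `CC(/C=N/Nc1ccc([N+](=O)[O-])cc1)=N\NC(=O)c1ccccc1F`, a limit only: > 12000 nM
Compound 2, `CC(/C=N/Nc1ccc([N+](=O)[O-])cc1)=N\NC(=O)c1ccc(C(C)(C)C)cc1`, a limit only: > 12000 nM
Compound 3, `CC(/C=N/N(C)c1ccc([N+](=O)[O-])cc1)=N\NC(=O)c1ccccc1O`: 3120 nM

Compound 1 stands at the limit of this assay, not at a number, and the same is true of compound 2; the limit of > 12000 nM in this assay, at which 2 of the 3 values shown sit, therefore covers two of the three values shown. Only compound 3, which differs from compound 1 in two places at once, gives a real number, and that number is still weak. Within the data shown here, no step between two measured compounds differing in a single place exists here, so nothing measured tells how a change at the fluoro position moves the read-out.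

Compound 4, `CC(/C=N/Nc1ccc([N+](=O)[O-])cc1)=N\NC(=O)c1ccccc1I`, is not yet measured. It is made from compound 1 by the change (iodo in place of fluoro on an aromatic carbon). With compound 1 already beyond the limit, the expected step that the limit leaves unreadable from compound 1 to compound 4 is none beyond the scatter, and compound 4 will most likely again be reported as a limit. Compound 4 is estimated at 15000 nM, within a range from 4000 nM to 60000 nM.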

Compound 4, half-maximal inhibitory concentration: 2980 nM
Compound 4: middle estimate off by 5.0-fold (0.70 log units), on the high side, and the stated range ends above it.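

Among these compounds, this is the only single change in the set that can be read, and it shows that the aromatic carbon ortho to a large group is not a silent place: in this assay, iodo in place of fluoro gives an at least 4.0-fold lower number from compound 1 to compound 4 (0.60 log units; beyond the scatter). Compound 1 carries only a limit of the assay, > 12000 nM, and not a number. The step therefore has a floor but no known full size, because compound 1 sits at that limit: the limit of > 12000 nM in this assay, at which 2 of the 4 values shown sit.

From the compounds shown here alone, whether chloro or bromo at the same place would give a number like that of compound 4, or whether a methyl or a methoxy group would do the same, stays open. Also open, going by these compounds, is whether iodo in place of the hydroxy group of compound 3 would lower its number.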